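A few compounds are considered here, and "the series" means these few. Any claim that something is new, unique, unknown or untested is made for them only; others in the source may bear on it.

Measured in a physicochemical assay for acid dissociation:
- compound 1 `NS(=O)(=O)c1ccc(S(=O)(=O)CCO)c(F)c1`: 9
- compound 2 `NS(=O)(=O)c1ccc(S(=O)(=O)CCCO)c(F)c1`: 9.02
- compound 3 `NS(=O)(=O)c1ccc(SCCCCO)c(F)c1`: 9.82

Compound 2, at 9.02, sits level with compound 1 within the scatter of this assay. Compound 3 shows the higher number, 9.82, and is the furthest from compound 2.

The next compound to be measured is compound 4 `NS(=O)(=O)c1ccc(S(=O)(=O)CCCO)c(C(=O)O)c1`. It is made from compound 2 by one structural change: carboxy in place of fluoro on an aromatic carbon. In words, carboxy stands in place of fluoro on an aromatic carbon, ortho to a group of 7 heavy atoms and meta to a sulfamoyl group.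

For the measured compounds named here, only one step between measured compounds differs in a single place: a number 0.02 log units higher from compound 1 to compound 2 (within the scatter). That change lies on the chain, not on the aromatic carbon, so it offers little guidance here. Compound 3 differs from compound 2 in more than one place, so its value does not isolate any single change. Going by the values given here, no measured compound carries a carboxy group, which leaves the size of this step uncertain.

A small rise is the tentative expectation, and the estimated step is a number 0.28 log units higher from compound 2 to compound 4 (within the scatter). Compound 4 is expected near 9.3, within an estimated range from 8.5 to 10.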

Compound 4, acid dissociation constant: 9.28
Compound 4: the middle estimate sits 0.02 log units above what was measured; low and high end bracket the measured number.
By their numbers in this assay, from the lowest: compounds 1, 2 and 4 (each within the scatter of the next); then compound 3.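

In this assay, putting carboxy in place of fluoro on the aromatic carbon, ortho to a group of 7 heavy atoms and meta to a sulfamoyl group, gives a number 0.26 log units higher from compound 2 to compound 4 (within the scatter), so the two compounds read as level. For the compounds shown here, the only earlier single-place step lay on the chain, and this result adds the first view of the aromatic carbon: here a fluoro group of 1 heavy atom, with no hydrogen-bond donor, gives way to a carboxy group of 3 heavy atoms, with 1 hydrogen-bond donor and 1 hydrogen-bond acceptor, and the reading stays within the scatter. Nothing among the data shown explains why the reading holds level across this change.

This single pair cannot tell whether other groups on the same aromatic carbon, such as an amine, a nitrile or a methyl ester, would also leave the number level. From the compounds shown here alone, it is also open whether carboxy in place of fluoro would give a similar step with a different chain, such as the shorter hydroxyethyl sulfonyl chain of compound 1.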